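Two Carbamoyl Cores, One Tail Exchange, Acid Ceramidase Inhibition

The source may report more compounds than this note shows. Statements on the series, on what has been measured and on what is new or still open speak of the compounds shown alone.

Measured compounds:
- compound 1 `O=C(NCCCCc1ccccc1)n1nnc2ccccc21`: 2.1 nM
- compound 2 `O=C(NCCCCc1ccccc1)N1C(=O)c2ccccc2C1=O`: 2.4 nM
- compound 3 `CCCCCCNC(=O)n1nnc2ccccc21`: 4.1 nM

Of the compounds shown here, three have been tested in an assay on HEK293 cells for inhibition of acid ceramidase (Homo sapiens), read by fluorescence, with stated times of 30 min and 1 h; a higher number here means a weaker inhibitor, a lower number a stronger inhibitor. Compound 1 gives 2.1 nM, compound 2 gives 2.4 nM and compound 3 gives 4.1 nM. All three numbers sit within the usual scatter of one another, so no order among them can be read from these data.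

Compound 1 and compound 2 carry different cores; the difference between the two cores is not broken down here. Compound 3 is derived from compound 1 by a single change, (ethyl in place of phenyl on a saturated chain carbon, four bonds along the chain from an amide-type nitrogen), and this change gave a 2.0-fold higher number from compound 1 to compound 3 (0.29 log units; within the scatter).

Compound 4 `CCCCCCNC(=O)N1C(=O)c2ccccc2C1=O` has not yet been measured. It is derived from compound 2 by the same change, (ethyl in place of phenyl on a saturated chain carbon, four bonds along the chain from an amide-type nitrogen), at the same place as in the pair already measured. The expectation for compound 4 therefore rests on a single measured instance of the change, that from compound 1 to compound 3, applied to the core of compound 2. Among the compounds with values here, the step expected here is a 2.0-fold higher number from compound 2 to compound 4 (0.30 log units; within the scatter), set beside the measured 2.0-fold higher number from compound 1 to compound 3 (0.29 log units; within the scatter), and it is worded as an expectation because a 2.0-fold higher number from compound 1 to compound 3 (0.29 log units; within the scatter) is the only guide available and lies within the scatter. In this assay compound 4 is expected to give about 4.8 nM, with a range from 2 nM to 12 nM.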

Compound 4, half-maximal inhibitory concentration in the acid ceramidase assay: 7 nM
The estimate for compound 4 lay 1.5-fold (0.16 log units) below the measured number; measured number inside the range.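

In the acid ceramidase assay, ethyl in place of phenyl gave a 2.9-fold higher number from compound 2 to compound 4 (0.46 log units; beyond the scatter), a modest step that, unlike the earlier one, stands clear of the scatter. Set beside that earlier step, the change carries from one core to the other with no difference that can be told apart: the same change on two cores in the acid ceramidase assay, a 2.0-fold higher number (0.29 log units; within the scatter) from compound 1 to compound 3 and a 2.9-fold higher number (0.46 log units; beyond the scatter) from compound 2 to compound 4, 1.5-fold (0.17 log units) apart, within the scatter of two such steps

This gives no sign that the core alters what the change does, but a single pair of cores cannot show that the same would hold on any other core. In a physicochemical assay for metabolic stability, read by HPLC, at pH 4.5, tested at 10 uM (on this read-out lower numbers stand for a shorter-lived compound and higher numbers for a longer-lived compound), compound 2 gives > 2 h, which is a limit and not a number. In the physicochemical assay compound 4 gives > 2 h, which is also a limit and not a number. In the physicochemical assay the step cannot be read, since both compounds give a limit and not a number: the limit of > 2 h in the physicochemical assay, at which 2 of the 2 values shown sit.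

Going by these compounds, it remains open whether an amine or a carboxylic acid in place of phenyl, or a longer chain, would give steps of like size on both cores in the acid ceramidase assay. Also open, on these data alone, is whether a third core would follow the same course, and how the two tails would compare in the physicochemical assay if each gave a number rather than a limit.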